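Piperazine amide series: cyano for trifluoromethoxy

The compounds below may be only part of what the source reports. "The series", "measured", "known", "first", "only" and "open" are said of these compounds alone.

Measured so far:
compound 1, `CCN(CC)c1ccc2cc(C(=O)c3ccc(N4CCN(C(=O)CN5CCN(C(=O)/C=C/c6ccccc6)CC5)CC4)cc3)oc2c1`: 13400 nM
compound 2, `CCN(CC)c1ccc2cc(C(=O)c3ccc(N4CCN(C(=O)CN5CCN(S(=O)(=O)c6ccc(OC(F)(F)F)cc6)CC5)CC4)cc3)oc2c1`: 20100 nM

In a functional assay on MCF7 cells (Homo sapiens) for cytotoxicity, read by MTT assay, with a stated time of 48 h (on this read-out higher numbers stand for weaker inhibition and lower numbers for stronger inhibition), compound 1 gives 13400 nM. In the same assay compound 2 gives 20100 nM, the higher of the two numbers, but the gap to compound 1 is within the scatter, so the two cannot be ranked against each other.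

Compound 3, `CCN(CC)c1ccc2cc(C(=O)c3ccc(N4CCN(C(=O)CN5CCN(S(=O)(=O)c6ccc(C#N)cc6)CC5)CC4)cc3)oc2c1`, keeps the shared core of compound 2 and changes only the terminal arylsulfonyl group: cyano in place of trifluoromethoxy on an aromatic carbon. Within the data shown here, no pair of measured compounds differs in this way, so there is no measured step to lean on. Among the measured compounds shown here, the only comparable change, the shift from the cinnamoyl amide of compound 1 to the arylsulfonyl of compound 2, stayed within the scatter, and a swap of one substituent on that ring is a smaller change still. The step from compound 2 to compound 3 is therefore expected to be small, a 1.1-fold lower number from compound 2 to compound 3 (0.05 log units; within the scatter), with no clear direction. Compound 3 is estimated at 18000 nM in this assay, within the range 7000 nM to 45000 nM.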

Compound 3, half-maximal inhibitory concentration: > 40000 nM
Compound 3: no number, only a limit; the forecaster's own chance of this, stated with the estimate: 15%; middle value at least 2.2-fold (0.34 log units) from the limit.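

In this assay compound 3 gives > 40000 nM, a limit and not a number, so the series now touches the top of what this read-out reports: the limit of > 40000 nM in this assay, at which 1 of the 3 values shown sits.

On the aromatic carbon para to a large group, 4-(trifluoromethoxy)phenyl to 4-cyanophenyl gives an at least 1.9-fold higher number from compound 2 to compound 3 (0.29 log units; that floor lies within the scatter), so the floor alone does not lift this swap out of the scatter, though it shows no gain in inhibition. The change on the amine nitrogen in a ring now gives an at least 2.9-fold higher number from compound 1 to compound 3 (0.47 log units; beyond the scatter), a step that clears the scatter, where the earlier pair of measured compounds did not.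

On these data alone, how far beyond the limit the cyano compound lies stays open, and with it the true size of both steps. Also open, as far as these compounds go, is how an amine or a carboxylic acid on that same aromatic carbon would read.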